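The source may report more compounds than this note shows. Statements on the series, on what has been measured and on what is new or still open speak of the compounds shown alone.

Measured compounds in a functional assay on the whole organism (artery, strain albino) with Rattus norvegicus as the target, with a stated time of 360 min, at a dose of 10 mg/kg by the oral route; a lower number here means less inhibition, a higher number more inhibition at the dose given (going by the name of the read-out):
Compound 1 `CC1=C(C(=O)Nc2ccc(Br)cc2)C(c2ccc(Cl)cc2Cl)N=C(SCc2ccc(Cl)cc2)N1` — compound 1 gives 39.7%
Compound 2 `CC1=C(C(=O)Nc2ccc(Br)cc2)C(c2ccc(Cl)cc2Cl)N=C(SCc2ccc(F)cc2)N1` — compound 2 gives 40.7%
Compound 3 `COc1ccc(C2N=C(SCc3ccc(Cl)cc3)NC(C)=C2C(=O)Nc2ccc(Br)cc2)cc1` — compound 3 gives 39.2%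

Compound 4 `COc1ccc(C2N=C(SCc3ccc(F)cc3)NC(C)=C2C(=O)Nc2ccc(Br)cc2)cc1` is not yet measured in this assay.

Compound 1 and compound 2 differ by fluoro in place of chloro on an aromatic carbon; the step in this assay is a number 1 percentage points higher from compound 1 to compound 2 (within the scatter). Compound 3 and compound 4 differ by fluoro in place of chloro on an aromatic carbon, the same change on a core that differs from that of compound 1 by 4-methoxyphenyl in place of 2,4-dichlorophenyl on a saturated ring carbon, a difference that in this assay gave a number 0.5 percentage points lower from compound 1 to compound 3 (within the scatter).

For compound 4 the step from compound 3 is expected to be a number 1 percentage points higher from compound 3 to compound 4 (within the scatter), resting on the earlier step of a number 1 percentage points higher from compound 1 to compound 2 (within the scatter), which stayed within the scatter. Compound 4 is therefore estimated at 40.2% in this assay, between 31% and 49%.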

Compound 4, a percentage reported as inhibition, in the whole organism at one dose (the size of the read-out at that dose, not a potency): 33.5%
Compound 4: the middle estimate sits 6.7 percentage points above what was measured; the range from low to high includes it.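

In this assay, fluoro in place of chloro gives a number 5.7 percentage points lower from compound 3 to compound 4 (within the scatter), and 4-methoxyphenyl in place of 2,4-dichlorophenyl gives a number 7.2 percentage points lower from compound 2 to compound 4 (within the scatter). Neither step can be told from the scatter, and the halogen change carries from one core to the other without a difference that can be resolved: the same change on two cores in this assay, a number 1 percentage points higher (within the scatter) from compound 1 to compound 2 and a number 5.7 percentage points lower (within the scatter) from compound 3 to compound 4, 6.7 percentage points apart, within the scatter of two such steps. Within the data shown here, this does not show that the steps are equal, only that these compounds at a single dose cannot separate them, and the aryl change reads the same way: the same change on two cores in this assay, a number 0.5 percentage points lower (within the scatter) from compound 1 to compound 3 and a number 7.2 percentage points lower (within the scatter) from compound 2 to compound 4, 6.7 percentage points apart, within the scatter of two such steps.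

Only chloro and fluoro appear on the benzyl ring in the compounds shown. From the compounds shown here alone, whether a nitrile or a carboxylic acid in place of the halogen, or a longer chain in place of the benzyl group, would give a step beyond the scatter stays open.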